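The compounds below may be only part of what the source reports. "The series", "measured", "known", "first", "only" and "open" are said of these compounds alone.

Measured compounds:
Compound 1 `CCc1ccccc1Nc1ncc2cc(Oc3ccnc(C(=O)NC)c3)ccc2n1` — in a physicochemical assay for solubility, at pH 7 (a higher number here means a more soluble compound, a lower number a less soluble compound), compound 1 gives < 1000 nM, which is a limit of the assay.
Compound 2 `CNC(=O)c1cc(Oc2ccc3nc(Nc4cccc(Br)c4)ncc3c2)ccn1` — in this assay compound 2 gives < 1000 nM, also a limit.
Compound 3 `CNC(=O)c1cc(Oc2ccc3nc(Nc4cccc(OC(F)(F)F)c4)ncc3c2)ccn1` — in this assay compound 3 gives < 1000 nM, again a limit.

Compound 3 thus stands where every measured value sits: at the limit of < 1000 nM in this assay, at which 3 of the 3 values shown sit. The change to compound 4 `CNC(=O)c1cc(Oc2ccc3nc(Nc4ccc(C(F)(F)F)cc4)ncc3c2)ccn1` is 4-(trifluoromethyl)phenyl in place of 3-(trifluoromethoxy)phenyl on a nitrogen on an aromatic ring. The measured steps that touch the same nitrogen, a step that the two limits leave unreadable from compound 1 to compound 3, a step that the two limits leave unreadable from compound 2 to compound 3 and a step that the two limits leave unreadable from compound 1 to compound 2, are all unreadable in size, so none gives a direction for exchanging the aryl group there. With nothing readable to lean on, the expected step that the limit leaves unreadable from compound 3 to compound 4 is none beyond the scatter. Compound 4 is estimated at 500 nM, within 100 nM to 2500 nM, and most likely reported once more only as a limit.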

Compound 4, solubility: < 1000 nM
Compound 4 ended at the assay's limit; the forecaster's own chance of this, stated with the estimate: 75%; the middle value does not contradict the limit.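

In this assay compound 4 gives < 1000 nM, which is a limit. No step among compounds 1, 2, 3 and 4 can be read: the limit of < 1000 nM in this assay, at which 4 of the 4 values shown sit.

The compounds shown leave open whether exchanging the aryl group on the nitrogen changes solubility at all, and in which direction.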